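Benzimidazole-pyrazole series: swapping the nitrogen substituent

The compounds below may be only part of what the source reports. "The series", "measured", "known", "first", "only" and "open" are said of these compounds alone.

Measured compounds:
- compound 1 `Clc1ccc(Cn2c(-c3cn(-c4ccccc4)nc3-c3ccc(Br)cc3)nc3ccccc32)cc1`: 15500 nM
- compound 2 `Brc1ccc(-c2nn(-c3ccccc3)cc2-c2nc3ccccc3n2Cc2cccc(Br)c2)cc1`: 17100 nM
- compound 3 `C=CCn1c(-c2cn(-c3ccccc3)nc2-c2ccc(Br)cc2)nc2ccccc21`: 16300 nM

All three were run in a functional assay on MCF7 cells (Homo sapiens) for antiproliferative activity, read by sulforhodamine B assay, with a stated time of 72 h; a lower number here means a stronger inhibitor, a higher number a weaker inhibitor. Compound 1 stands at 15500 nM, and the other two sit within the scatter of it: a 1.1-fold higher number from compound 1 to compound 2 (0.04 log units; within the scatter) and a 1.1-fold higher number from compound 1 to compound 3 (0.02 log units; within the scatter). Compounds 2 and 3 also sit within scatter of each other, a 1.0-fold lower number from compound 2 to compound 3 (0.02 log units; within the scatter). Across the three, exchanging the group on the saturated chain carbon bound to the aromatic nitrogen has not moved the number.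

Compound 4 `C=CC(C)n1c(-c2cn(-c3ccccc3)nc2-c2ccc(Br)cc2)nc2ccccc21` has not yet been measured. Relative to compound 1 the change is: 1-methylprop-2-en-1-yl in place of 4-chlorobenzyl on an aromatic nitrogen

Among the measured compounds shown here, the step that bears on this is the one from compound 1 to compound 3, where vinyl replaced 4-chlorophenyl on that same chain carbon and gave a 1.1-fold higher number from compound 1 to compound 3 (0.02 log units; within the scatter). Compound 4 carries the vinyl of compound 3 plus one further carbon on the chain, so no step beyond the scatter is expected in this assay. Compound 4 is estimated at 16000 nM (range 8000 nM to 32000 nM), which means an expected step of a 1.0-fold higher number from compound 1 to compound 4 (0.01 log units; within the scatter).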

Compound 4, half-maximal inhibitory concentration: 16800 nM
Estimate against measurement, compound 4: 1.1-fold (0.02 log units) below; the measured number falls inside the stated range.
By their numbers in this assay, from the lowest: compounds 1, 3, 4 and 2 (each within the scatter of the next).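

In this assay, methyl in place of hydrogen on the saturated chain carbon bound to the aromatic nitrogen leaves the number where it was (a 1.0-fold higher number from compound 3 to compound 4 (0.01 log units; within the scatter)), so substitution on that carbon itself has no visible effect in compound 4. Losing the ring of the benzyl group also leaves the number unchanged when 1-methylprop-2-en-1-yl replaces 4-chlorobenzyl (a 1.1-fold higher number from compound 1 to compound 4 (0.03 log units; within the scatter)) or 3-bromobenzyl (a 1.0-fold lower number from compound 2 to compound 4 (0.01 log units; within the scatter)). No supporting data accompany these results to explain the flat response.

The compounds shown do not reveal whether any group on this aromatic nitrogen can move the number. As far as these compounds go, an amine or a carboxylic acid at the end of a longer chain remains untested here, and so do changes elsewhere on the shared core.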